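The source may hold more compounds than are shown below. What is called first, only, known or untested is meant among the compounds shown, and "the series" means these compounds.

Compound 2, `O=C(Nc1ccc(Cl)c(-c2nnc3c(Cl)cccn23)c1)c1ccc(Cl)cc1`, is one of two close relatives tested for how well they slow the growth of a breast cancer cell line. In a functional assay on MDA-MB-468 cells (Homo sapiens) for antiproliferative activity, read by MTT assay, with a stated time of 72 h (a higher number here means a weaker inhibitor, a lower number a stronger inhibitor), compound 2 gives > 100000 nM, which is a limit of the assay rather than a number. Its neighbour compound 1, `O=C(Nc1ccc(Cl)c(-c2nnc3c(Cl)cccn23)c1)c1ccccc1Cl`, differs only in the chlorophenyl group on the carbonyl carbon. In this assay compound 1 gives > 100000 nM, again a limit. The step between them, a step that the two limits leave unreadable from compound 1 to compound 2, cannot be read because of the limit of > 100000 nM in this assay, at which 2 of the 2 values shown sit.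

The next compound, compound 3, `O=C(Nc1ccc(Cl)c(-c2nnc3c(Cl)cccn23)c1)c1cccnc1`, changes the same part of the molecule: pyridin-3-yl in place of 4-chlorophenyl on a carbonyl carbon. Going by the values given here, the only measured step that touches this position is the one from compound 1 to compound 2, and it gives no usable size. With both measured values sitting at the limit, no direction can be read for this assay, and the expectation is that compound 3 also stays at or beyond the limit. Compound 3 is therefore estimated at 150000 nM, with a range from 30000 nM to 500000 nM, which means an expected step that the limit leaves unreadable from compound 2 to compound 3.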

Compound 3, half-maximal inhibitory concentration: > 100000 nM
Compound 3 ended at the assay's limit; the forecaster's own chance of this, stated with the estimate: 85%; the middle value lies beyond the limit too.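

No step to compound 3 can be read, from either compound 1 or compound 2, and the reason is the same for both: the limit of > 100000 nM in this assay, at which 3 of the 3 values shown sit. The compounds shown leave open how the 2-chlorophenyl, 4-chlorophenyl and pyridin-3-yl groups on the carbonyl carbon compare in this assay, where all three values are limits and not numbers.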